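The source may hold more compounds than are shown below. What is called first, only, known or untested is meant among the compounds shown, and "the series" means these compounds.

In a functional assay on L1210 cells (Mus musculus) for antiproliferative activity, with a stated time of 48 h (on this read-out lower numbers stand for stronger inhibition and higher numbers for weaker inhibition), compound 1 (`C=C(Br)C(=O)Nc1ccc(C(=O)/C=C/c2cccc(OC)c2)cc1`) gives 1100 nM and compound 2 (`C=C(Br)C(=O)Nc1ccc(C(=O)/C=C/c2cccc(OC)c2OC)cc1`) gives 1100 nM, so the two stand level. Among the compounds with values here, the only measured step, no change at the digits printed from compound 1 to compound 2 (within the scatter), is methoxy in place of hydrogen on an aromatic carbon.

Compound 3 (`COc1cccc(/C=C/C(=O)c2ccc(N)cc2)c1`) departs from compound 1 at a different place: hydrogen in place of (1-bromoethenyl)carbonyl on a nitrogen on an aromatic ring. In words, this is hydrogen in place of (1-bromoethenyl)carbonyl on a nitrogen on an aromatic ring, which turns ((1-bromoethenyl)carbonyl)amino into amino.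

The methoxy step bears on this only weakly. Within the data shown here, it shows that one edit elsewhere on the molecule left the number in place, but both measured compounds carry the (1-bromoethenyl)carbonyl group, and no measured compound lacks it. The data therefore give no direct measure of what its loss does. Since this change removes a whole group rather than adding a small one, a clear loss of inhibition seems the likelier outcome, though this is a judgement and not a measured trend.

The expected change is an 11-fold higher number from compound 1 to compound 3 (1.04 log units; beyond the scatter), towards weaker inhibition. For compound 3 the estimated value is 12000 nM, with an expected range from 3000 nM to 50000 nM.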

Compound 3, half-maximal inhibitory concentration: 22000 nM
Compound 3: the middle estimate sits 1.8-fold (0.26 log units) below what was measured; low and high end bracket the measured number.
By their numbers in this assay, from the lowest: compounds 1 and 2 (each within the scatter of the next); then compound 3.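

Taking the (1-bromoethenyl)carbonyl group off the nitrogen gives a 20-fold higher number from compound 1 to compound 3 (1.30 log units; beyond the scatter) in this assay and turns the ((1-bromoethenyl)carbonyl)amino group into a plain amino group. Unlike the methoxy step, which left the number in place, this change at the nitrogen moves the number well beyond the usual scatter, so the group counts for much of the inhibition seen with compound 1. Yet compound 3 still gives 22000 nM in this read-out, so the remaining structure keeps some measurable inhibition without the group, and nothing at hand explains the size of this step.

The compounds shown leave open which part of the departing group matters, since the bromine, the double bond and the carbonyl all leave together; an acetyl group or an ethenylcarbonyl group on the same nitrogen would help to tell these parts apart. They also leave open whether a (1-chloroethenyl)carbonyl group could stand in for the (1-bromoethenyl)carbonyl group, and whether the second methoxy group of compound 2 would matter once the nitrogen carries only hydrogen.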